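The source may hold more compounds than are shown below. What is called first, only, known or untested is meant among the compounds shown, and "the series" means these compounds.

- Compound 1 `CC1=C(c2cccc(O)c2)C(c2ccc(OC[C@H](C)N3CCCC3)cc2)Oc2ccc(O)cc21`: 0.2 nM
- Compound 2 `CC1=C(c2cccc(O)c2)C(c2ccc(OC[C@H](C)N3CC[C@@H](C)C3)cc2)Oc2ccc(O)cc21`: 0.2 nM

Among the measured compounds shown here, in a functional assay on MCF7 cells (Homo sapiens) for antiproliferative activity, read by CellTiter-Glo, with a stated time of 5 days (on this read-out lower numbers stand for stronger inhibition and higher numbers for weaker inhibition), compound 2 gives 0.2 nM, level with compound 1, the only other measured compound. Compound 3 `CC1=C(c2cccc(O)c2)C(c2ccc(OC[C@@H](C)N3CC[C@@H](C)C3)cc2)Oc2ccc(O)cc21` differs from it as follows: the two compounds have the same atoms and bonds; at least one stereo element is drawn with a configuration in one of them and without one in the other: 1 of 3 stereo elements differ; a stereocentre at a saturated chain carbon is drawn S in compound 2 and R in compound 3. For the measured compounds named here, the sole measured step, no change at the digits printed from compound 1 to compound 2 (within the scatter), concerns methyl in place of hydrogen on a saturated ring carbon, so it is a different change and bears only indirectly. No inversion at this chain carbon has been measured, and the data give no direction. No step beyond the scatter is therefore expected in this assay, although the range stays wider on the weaker side. Compound 3 is expected at 0.4 nM, with an estimated range of 0.15 nM to 2 nM. This estimate corresponds to an expected 2.0-fold higher number from compound 2 to compound 3 (0.30 log units; within the scatter).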

Compound 3, half-maximal inhibitory concentration: 0.2 nM
Estimate against measurement, compound 3: 2.0-fold (0.30 log units) above, and the stated range covers the measured number.
By their numbers in this assay, from the lowest: compounds 1, 2 and 3 (each within the scatter of the next).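

In this assay, among the compounds shown here, inverting the saturated chain carbon from S to R gives no change at the digits printed from compound 2 to compound 3 (within the scatter), so this stereocentre, untested by the earlier compounds, can be inverted without a step beyond the scatter. Taking the methyl on the ring and the inversion together gives no change at the digits printed from compound 1 to compound 3 (within the scatter). One caveat applies to reading the inversion: the fact that one of compounds 2 and 3 is drawn with a defined configuration and the other without, at the place where they differ

Still open, going by these compounds, is whether this tolerance at the chain carbon holds when a piperidine ring or a dimethylamino group replaces the five-membered non-aromatic ring.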